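This account rests on a few compounds, and the source may have more. Where it says the series, first, only, none or still open, it means among the compounds named here.

Compound 3 `CNc1nc(Cl)nc2c1ncn2[C@@H]1O[C@H](C(=O)N2CCOCC2)[C@@H](O)[C@H]1O` has the highest number of the three measured compounds in an assay on CHO cells for displacement of a labelled ligand from adenosine receptor A3 (Homo sapiens); on this read-out higher numbers stand for weaker inhibition and lower numbers for stronger inhibition: compound 3 gives 3890 nM, while compound 1 `CNc1nc(Cl)nc2c1ncn2[C@@H]1O[C@H](C(=O)N(C)C)[C@@H](O)[C@H]1O` gives 1510 nM and compound 2 `CNc1nc(Cl)nc2c1ncn2[C@@H]1O[C@H](C(=O)NCCC(C)C)[C@@H](O)[C@H]1O` gives 1.62 nM. Compound 4 `CNc1nc(Cl)nc2c1ncn2[C@@H]1O[C@H](C(=O)NCc2cccc(F)c2)[C@@H](O)[C@H]1O` differs from compound 3 by one change: (3-fluorobenzyl)amino in place of morpholin-4-yl on a carbonyl carbon. The step that bears on this is a 2400-fold higher number from compound 2 to compound 3 (3.38 log units; beyond the scatter), where the amide with a hydrogen on its nitrogen was far stronger than the ring-closed amide; a 2.6-fold higher number from compound 1 to compound 3 (0.41 log units; beyond the scatter) shows that both ring-closed and dimethyl amides are weak. Because compound 2 reached 1.62 nM with such an open amide, compound 4 is expected to show a large drop in number, a 190-fold lower number from compound 3 to compound 4 (2.29 log units; beyond the scatter). The estimated value for compound 4 is 20 nM, within a range of 3 nM to 150 nM.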

Compound 4, inhibition constant: 17.4 nM
For compound 4 the middle estimate is 1.1-fold (0.06 log units) above the measured one, and the stated range covers the measured number.
By their numbers in this assay, from the lowest: compound 2; then compound 4; then compound 1; then compound 3.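

At this carbonyl carbon, low numbers in this assay are not confined to the isopentylamino group: (3-fluorobenzyl)amino, which brings an aromatic ring, also gives large falls, with a 220-fold lower number from compound 3 to compound 4 (2.35 log units; beyond the scatter) and an 87-fold lower number from compound 1 to compound 4 (1.94 log units; beyond the scatter). Even so, the aromatic group does not match the open chain, with an 11-fold higher number from compound 2 to compound 4 (1.03 log units; beyond the scatter). No evidence is available on the reason for these differences.

As far as these compounds go, whether the fluorine contributes remains open. So does how a plain benzylamino group or a longer phenethylamino chain would compare on this carbonyl carbon.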